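A few compounds are considered here, and "the series" means these few. Any claim that something is new, unique, unknown or untested is made for them only; others in the source may bear on it.

Measured compounds in the series:

compound 1, `CC[C@H](c1ccc(C(=O)O)c(Oc2cccc(Cl)c2)c1F)N1CCC[C@H](n2cc(C)c(=O)[nH]c2=O)C1` — 119 mL/min/kg
compound 2, `CC[C@H](c1ccc(C(=O)O)c(Oc2cccc(Cl)c2)c1OC)N1CCC[C@H](n2cc(C)c(=O)[nH]c2=O)C1` — 84 mL/min/kg
compound 3, `CCC[C@H](c1ccc(C(=O)O)c(Oc2cccc(Cl)c2)c1F)N1CCC[C@H](n2cc(C)c(=O)[nH]c2=O)C1` — 64 mL/min/kg

In an ADME assay on the whole organism (strain Wistar) for pharmacokinetics, with Rattus norvegicus as the target, given by the intravenous route (on this read-out higher numbers stand for fast clearance and lower numbers for slow clearance), compound 2 gives 84 mL/min/kg and stands second highest of the three numbers. Its nearest neighbour is compound 3 and its furthest is compound 1, and the gaps to both are within the scatter, so the three measured compounds cannot be ranked against each other on this read-out.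

The next compound, compound 4, `CC[C@@H](c1ccc(C(=O)O)c(Oc2cccc(Cl)c2)c1OC)N1CCC[C@H](n2cc(C)c(=O)[nH]c2=O)C1`, has not yet been measured in this assay. Relative to compound 2 it differs as follows: the two compounds have the same atoms and bonds and differ only in configuration as drawn: 1 of 2 stereo elements differ; a stereocentre at a saturated chain carbon is drawn R in compound 2 and S in compound 4.

Neither of the measured steps concerns a change of configuration. The two that exist, a 1.4-fold lower number from compound 1 to compound 2 (0.15 log units; within the scatter) and a 1.9-fold lower number from compound 1 to compound 3 (0.27 log units; within the scatter), each exchange one group at a single position, and each lies within the scatter. Among the compounds with values here, no step shows what inverting this stereocentre does to clearance, in either direction, so the change from compound 2 to compound 4 rests on no precedent here.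

The step expected from compound 2 to compound 4 is therefore a 1.0-fold higher number from compound 2 to compound 4 (0.01 log units; within the scatter), a number held near that of compound 2 but with a wide range to allow for an effect of the inverted centre in either direction. For compound 4 the estimate in this assay is 85 mL/min/kg, with a range from 42 mL/min/kg to 170 mL/min/kg.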

Compound 4, clearance: 73 mL/min/kg
The estimate for compound 4 lay 1.2-fold (0.07 log units) above the measured number; low and high end bracket the measured number.
By their numbers in this assay, from the lowest: compounds 3, 4, 2 and 1 (each within the scatter of the next).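

The stereocentre at the saturated chain carbon, drawn R in compound 2 and S in compound 4, now has a measured step in this assay: a 1.2-fold lower number from compound 2 to compound 4 (0.06 log units; within the scatter). On this read-out, and with methoxy on the aromatic carbon, the two configurations at this centre cannot be told apart, a limit that holds for this one pair and not for the series as a whole. The earlier steps each exchanged a group at one place, whereas this comparison isolates configuration alone, and it rests on a single clean pair: the fact that compounds 2 and 4 differ only in the configuration as drawn

Still open is whether the two configurations at this centre also stay within the scatter of each other with the fluoro group of compound 1 or the longer chain of compound 3, since neither of these compounds has a partner of opposite configuration among those shown. Also open, on these data alone, is how clearance responds to a cyclopropyl group on this chain carbon, or to an amide or a tetrazole in place of the carboxylic acid, and what the other stereocentre contributes.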